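The source may report more compounds than this note shows. Statements on the series, on what has been measured and on what is new or still open speak of the compounds shown alone.

Measured compounds and values:
- compound 1 `Cc1nc(-c2ccc(F)cc2)sc1COc1ccc(OCC(=O)O)c(F)c1`: in an assay on CHO cells for agonist activity at Free fatty acid receptor 1 (Homo sapiens), read by FLIPR (a lower number here means that less compound is needed, a higher number that more compound is needed for the effect), compound 1 gives 112 nM
- compound 2 `Cc1nc(-c2cccc(F)c2)sc1COc1ccc(OCC(=O)O)c(F)c1`: compound 2 gives 185 nM
- compound 3 `Cc1ccc(-c2nc(C)c(COc3ccc(OCC(=O)O)c(F)c3)s2)cc1`: compound 3 gives 156 nM

All three share the same core and differ only in the aryl group carried on the five-membered ring. Compound 3 stands second highest of the three numbers, nearest compound 2 and furthest from compound 1, and every one of these gaps lies within the scatter: a 1.4-fold higher number from compound 1 to compound 3 (0.14 log units; within the scatter), a 1.2-fold lower number from compound 2 to compound 3 (0.07 log units; within the scatter).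

Compound 4 `Cc1cccc(-c2nc(C)c(COc3ccc(OCC(=O)O)c(F)c3)s2)c1` is the next entry. It carries 3-methylphenyl in place of 4-methylphenyl on an aromatic carbon. Among the compounds with values here, the one measured step of the same kind is the move of the fluoro substituent between compounds 1 and 2, a 1.7-fold higher number from compound 1 to compound 2 (0.22 log units; within the scatter), a shift that did not leave the scatter. Within the data shown here, nothing among the measured steps points to a larger effect for the methyl series, so only a small movement is anticipated, if any, and a slightly higher number is the more likely direction.

Compound 4 is therefore expected to give 220 nM (range 110 nM to 450 nM); the expected step is a 1.4-fold higher number from compound 3 to compound 4 (0.15 log units; within the scatter).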

Compound 4, half-maximal effective concentration: 247 nM
Beside the measured number, compound 4's estimate is 1.1-fold (0.05 log units) below it; low and high end bracket the measured number.
By their numbers in this assay, from the lowest: compounds 1, 3, 2 and 4 (each within the scatter of the next, the first and the last beyond it).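

In this assay, 3-methylphenyl in place of 4-methylphenyl gives a 1.6-fold higher number from compound 3 to compound 4 (0.20 log units; within the scatter), so on this aromatic carbon of the five-membered ring the two methylphenyl isomers cannot be told apart. Within the data shown here, the only step in the set that leaves the scatter is modest and joins the two ends of the series, a 2.2-fold higher number from compound 1 to compound 4 (0.34 log units; beyond the scatter), in which 3-methylphenyl replaces 4-fluorophenyl. Methyl in place of fluoro gives a 1.3-fold higher number from compound 2 to compound 4 (0.13 log units; within the scatter), and this swap now reads alike with the substituent in either place on the phenyl ring: the same change on two cores in this assay, a 1.4-fold higher number (0.14 log units; within the scatter) from compound 1 to compound 3 and a 1.3-fold higher number (0.13 log units; within the scatter) from compound 2 to compound 4, 1.0-fold (0.02 log units) apart, within the scatter of two such steps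

The phenyl substituents shown are limited to methyl and fluoro, so the response to an amine, a carboxylic acid or a longer chain such as butyl on that ring remains open. Going by these compounds, whether any group at this position can move the number by more than a modest step also remains open.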